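This account rests on a few compounds, and the source may have more. Where it says the series, first, only, none or still open, it means among the compounds named here.

Of the compounds shown here, three have so far been measured in a functional assay on thoracic aorta (Rattus norvegicus, strain Wistar), with a stated time of 15 min; on this read-out higher numbers stand for an effect only at larger amounts of compound and lower numbers for an effect already at smaller amounts. Compound 1 (`CCOc1ccc(F)cc1C(C)NC(=O)N(C)S(=O)(=O)c1ccc(C)cc1`) gives 7800 nM, compound 2 (`COc1ccc(F)cc1C(C)NC(=O)N(C)S(=O)(=O)c1ccc(Cl)cc1`) gives 12600 nM, and compound 3 (`COc1ccc(Cl)cc1C(C)NC(=O)N(C)S(=O)(=O)c1ccc(C)cc1`) gives 13800 nM. Compound 3 thus lies within the scatter of both others. Compound 4 (`COc1ccc(F)cc1C(C)NC(=O)N(C)S(=O)(=O)c1ccc(C)cc1`) has not yet been measured. It differs from compound 3 in one place: fluoro in place of chloro on an aromatic carbon, para to a methoxy group. Within the data shown here, no measured pair isolates this change, but compound 1 and compound 2 both carry fluoro there and stay within the scatter of compound 3, so no step beyond the scatter is expected in this assay. The estimated step is a 1.3-fold lower number from compound 3 to compound 4 (0.10 log units; within the scatter). For compound 4 the expected value is 11000 nM, with an estimated range of 5500 nM to 22000 nM.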

Compound 4, half-maximal effective concentration: 11700 nM
Beside the measured number, compound 4's estimate is 1.1-fold (0.03 log units) below it; measured number inside the range.
By their numbers in this assay, from the lowest: compounds 1, 4, 2 and 3 (each within the scatter of the next).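

In this assay, fluoro in place of chloro on the aromatic carbon para to a methoxy group now has a direct reading (a 1.2-fold lower number from compound 3 to compound 4 (0.07 log units; within the scatter)), and this swap leaves the number within the scatter. The two other single changes read alike: a chloro group swapped for a methyl group on the aromatic ring of the sulfonyl part (a 1.1-fold lower number from compound 2 to compound 4 (0.03 log units; within the scatter)) and hydrogen in place of methyl on a saturated chain carbon bound to an oxygen on an aromatic ring (a 1.5-fold higher number from compound 1 to compound 4 (0.18 log units; within the scatter)). No measurement shown explains these results. On these data alone, whether an amine or a carboxylic acid at the fluoro position would give a step beyond the scatter stays open.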